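Amide nitrogen substituent change from compound 2 to compound 3

The source may hold more compounds than are shown below. What is called first, only, known or untested is meant among the compounds shown, and "the series" means these compounds.

In a functional assay on SK-BR-3 cells (Homo sapiens) for inhibition, read by MTT assay (on this read-out higher numbers stand for weaker inhibition of growth and lower numbers for stronger inhibition of growth), compound 1 `CC1=C(/C=C/C(C)=C/C=C/C(C)=C\C(=O)Nc2ccccc2)C(C)(C)CCC1n1ccnc1` gives 1730 nM and compound 2 `CC1=C(/C=C/C(C)=C/C=C/C(C)=C\C(=O)Nc2ccc(O)cc2)C(C)(C)CCC1n1ccnc1` gives 3890 nM, which is the higher of the two numbers and so the weaker inhibition of growth. Compound 3 `CC1=C(/C=C/C(C)=C/C=C/C(C)=C\C(=O)NCc2cccc(F)c2)C(C)(C)CCC1n1ccnc1` has not yet been measured. Its structural change is 3-fluorobenzyl in place of 4-hydroxyphenyl on an amide-type nitrogen. Within the data shown here, only one measured step bears on this change: a 2.2-fold higher number from compound 1 to compound 2 (0.35 log units; beyond the scatter), a modest step beyond the scatter, for hydroxy in place of hydrogen on an aromatic carbon. Compound 3 carries no hydroxy, so that step is the nearest guide, and it suggests a number lower than that of compound 2. The guide is only partial, since no measured compound carries 3-fluorobenzyl on this nitrogen, and the range is kept wide for that reason. The expected step, a 1.9-fold lower number from compound 2 to compound 3 (0.29 log units; within the scatter), is of similarly modest size, towards stronger inhibition. In this assay, the estimate for compound 3 is 2000 nM, with the result expected between 800 nM and 5000 nM.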

Compound 3, concentration for 50% growth inhibition: 4240 nM
Compound 3: middle estimate off by 2.1-fold (0.33 log units), on the low side; measured number inside the range.
By their numbers in this assay, from the lowest: compound 1; then compounds 2 and 3 (each within the scatter of the next).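

In this assay, the step of a 1.1-fold higher number from compound 2 to compound 3 (0.04 log units; within the scatter) leaves 3-fluorobenzyl and 4-hydroxyphenyl on this amide-type nitrogen not told apart, although 3-fluorobenzyl counts 0 hydrogen-bond donors and 4-hydroxyphenyl counts 1. The step of a 2.5-fold higher number from compound 1 to compound 3 (0.39 log units; beyond the scatter) is modest but beyond the scatter, so compound 1, with plain phenyl on this nitrogen, keeps the lowest number of the three, and compound 3 shows that a number on the level of compound 2 does not depend on the presence of a hydroxy group. Nothing in hand explains why these groups read as they do.

The compounds shown leave open whether the step from phenyl to 3-fluorobenzyl comes from the added benzyl carbon or from the fluorine, a question that plain benzyl on the same nitrogen would help to settle. Also open, going by these compounds, is how an amine or a carboxylic acid on the benzyl ring would read in this assay.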